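Swapping the Group on the Saturated Ring Carbon

A few compounds are considered here, and "the series" means these few. Any claim that something is new, unique, unknown or untested is made for them only; others in the source may bear on it.

Measured compounds:
compound 1, `COc1ccc([C@@H]2CC(c3cccc(O)c3)=NN2c2ccc(S(N)(=O)=O)cc2)cc1`, 64.7%
compound 2, `COc1ccc([C@@H]2CC(c3cccc(O)c3)=NN2c2ccc(S(N)(=O)=O)cc2)cc1OC`, 55.9%

In a functional assay on the whole organism (strain Wistar albino) for inhibition, with Rattus norvegicus as the target, read by paw edema, with stated times of 30 min and 3 h, at a dose of 0.05 mmol/kg (on this read-out higher numbers stand for more inhibition at the one dose given (going by the name of the read-out) and lower numbers for less inhibition), compound 1 gives 64.7%, and compound 2 gives 55.9%. For the measured compounds named here, the single measured step, a number 8.8 percentage points lower from compound 1 to compound 2 (within the scatter), comes from a methoxy in place of hydrogen on an aromatic carbon. Compound 2 therefore holds the smaller of the two numbers, yet its gap to compound 1 lies within the scatter, so the two compounds cannot be told apart in this assay.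

Compound 3 `NS(=O)(=O)c1ccc(N2N=C(c3cccc(O)c3)C[C@H]2/C=C/c2ccccc2)cc1` is not yet measured. It differs from compound 2 in one place: 2-phenylethenyl in place of 3,4-dimethoxyphenyl on a saturated ring carbon. Going by the values given here, no measured step touches the group on the saturated ring carbon; the one step that exists alters a methoxy on an aromatic carbon and stays within the scatter. There is thus no measured basis for expecting a step beyond the scatter in this assay, and the expected step of a number 2.1 percentage points higher from compound 2 to compound 3 (within the scatter) reflects that. For compound 3 the estimated value is 58%, with an expected range from 40% to 75%.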

Compound 3, a percentage reported as inhibition, in the whole organism at one dose (the size of the read-out at that dose, not a potency): 39.9%
Estimate against measurement, compound 3: 18.1 percentage points above; measured number below the stated range.
By their numbers in this assay, from the lowest: compound 3; then compounds 2 and 1 (each within the scatter of the next).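

For the compounds shown here, this position is the first place where a change moves the number beyond the usual scatter. In this assay, putting 2-phenylethenyl in place of 3,4-dimethoxyphenyl on the saturated ring carbon gives a number 16 percentage points lower from compound 2 to compound 3 (beyond the scatter) and putting it in place of 4-methoxyphenyl gives a number 24.8 percentage points lower from compound 1 to compound 3 (beyond the scatter) so both compounds with a phenyl ring attached directly at this carbon hold higher numbers than the compound carrying the 2-phenylethenyl group, whereas the extra methoxy separating compound 1 from compound 2 made no distinction beyond the scatter. No supporting measurement is available to explain this drop.

The compounds shown leave open which part of the change matters: the double bond, the distance of the phenyl ring from the saturated ring carbon, or the loss of the methoxy groups. A 2-phenylethyl group, an unsubstituted phenyl or a 4-aminophenyl group at this carbon would help separate these possibilities, and a shorter chain such as ethyl would show how much of the outer ring is needed at all.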